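This account rests on a few compounds, and the source may have more. Where it says the series, first, only, none or still open, it means among the compounds named here.

Measured compounds:
- compound 1 `COc1cc2nc(N3CCN(C(=O)c4ccco4)CC3)cc(N)c2cc1OC`, 0.14 nM
- compound 2 `COc1cc2nc(N3CCN(c4nccc(N(C)C)n4)CC3)cc(N)c2cc1OC`, 0.46 nM
- compound 3 `COc1cc2nc(N(C)C)cc(N)c2cc1OC`, 11.4 nM

In an assay on brain for displacement of a labelled ligand from Adrenergic receptor alpha-1 (Rattus norvegicus) (on this read-out lower numbers stand for stronger inhibition and higher numbers for weaker inhibition), compound 2 gives 0.46 nM, the second highest of the three numbers; compound 1 sits closest to it and compound 3 furthest away. Compound 4 `COc1cc2nc(N3CCN(C(=O)Nc4ccccc4)CC3)cc(N)c2cc1OC` is not yet measured. It differs from compound 2 in one place: phenylcarbamoyl in place of 4-(dimethylamino)pyrimidin-2-yl on an amine nitrogen in a ring. For the measured compounds named here, the only measured step at this ring nitrogen is a 3.3-fold higher number from compound 1 to compound 2 (0.52 log units; beyond the scatter), which exchanged a carbonyl-linked group for the pyrimidinyl group. Compound 4 again carries a carbonyl-linked group on that nitrogen, so the step is expected to run back toward compound 1, though the urea is not the same group as the furan amide and the change may stay small. Compound 4 is therefore estimated at 0.3 nM (range 0.1 nM to 1 nM), a step of a 1.5-fold lower number from compound 2 to compound 4 (0.19 log units; within the scatter) expected.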

Compound 4, inhibition constant: 0.34 nM
Compound 4: the middle estimate sits 1.1-fold (0.05 log units) below what was measured, within the range that was stated.
By their numbers in this assay, from the lowest: compound 1; then compounds 4 and 2 (each within the scatter of the next); then compound 3.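

In this assay, phenylcarbamoyl and 4-(dimethylamino)pyrimidin-2-yl on the ring nitrogen cannot be told apart (a 1.4-fold lower number from compound 2 to compound 4 (0.13 log units; within the scatter)), so two quite different groups of equal heavy-atom count give matching numbers here. A carbonyl on this nitrogen does not alone set the number, since anilino and furan-2-yl on that carbonyl carbon do separate (a 2.4-fold higher number from compound 1 to compound 4 (0.39 log units; beyond the scatter)). Nothing available accounts for either step.

Still open, as far as these compounds go, is whether a cyclohexylamino group on the carbonyl carbon would stay close to compound 4, or whether a methyl on the urea nitrogen would shift the number.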